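Chloro Added to Compound 1: Expected Tolerance

The compounds below may be only part of what the source reports. "The series", "measured", "known", "first", "only" and "open" are said of these compounds alone.

Compound 1 `CCN(c1ccccc1C)S(=O)(=O)c1cc(Cl)ccc1Cl` gives > 25000 nM in an ADME assay on A549 cells (Homo sapiens) for cytotoxicity, read by MTT assay (a higher number here means that more compound is tolerated, a lower number that less compound is tolerated), which is a limit of the assay and not a number.
Compound 2 `Cc1ccccc1NS(=O)(=O)c1cc(Cl)ccc1Cl` gives > 5000 nM in this assay, also only a limit.
Compound 3 `Cc1ccccc1N(C(C)C)S(=O)(=O)c1cc(Cl)ccc1Cl` gives > 5000 nM in this assay, again only a limit.

Compound 1 stands at a limit: the limit of > 25000 nM in this assay, at which 1 of the 3 values shown sits, holds its value, while the limit of > 5000 nM in this assay, at which 2 of the 3 values shown sit, holds the other two, so no order among the three can be read. The steps a step that the two limits leave unreadable from compound 1 to compound 2, a step that the two limits leave unreadable from compound 1 to compound 3 and a step that the two limits leave unreadable from compound 2 to compound 3 are all unreadable between limits. Compound 4 `CCN(c1ccc(Cl)cc1C)S(=O)(=O)c1cc(Cl)ccc1Cl` differs from compound 1 by chloro in place of hydrogen on an aromatic carbon. Going by the values given here, no measured step bears readably on this change. Compound 4 is therefore expected near 25000 nM, with a range of 8000 nM to 80000 nM, most likely reported again as a limit. The expected step of a number no higher from compound 1 to compound 4 (the limit leaves the size open) is small.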

Compound 4, half-maximal cytotoxic concentration: > 5000 nM
Compound 4 ended at the assay's limit; the forecaster's own chance of this, stated with the estimate: 70%; the middle value lies beyond the limit too.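

Compound 1 and compound 4 both give limits and not numbers, so the step between them cannot be read. The compounds shown leave open whether this added chloro changes how much compound is tolerated in this assay.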